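The source may report more compounds than this note shows. Statements on the series, on what has been measured and on what is new or still open speak of the compounds shown alone.

The measured compounds:
Compound 1, `O=C(O)Cc1sc(C(c2ccc(F)cc2)c2ccc(F)cc2)nc1-c1ccnc(N2CCC2)c1`: in an in vitro functional assay on HEK285-7 cells for antagonist activity at prostaglandin D2 receptor 2 (Homo sapiens), read by BRET and beta-arrestin recruitment (on this read-out higher numbers stand for weaker inhibition and lower numbers for stronger inhibition), compound 1 gives > 100000 nM, which is a limit of the assay rather than a number.
Compound 2, `COc1cc(-c2nc(C(c3ccc(F)cc3)c3ccc(F)cc3)sc2CC(=O)O)ccn1`: in this assay compound 2 gives 380 nM.

Going by the values given here, compound 2 therefore stands as the only compound with a numerical value; the one other value shown is a limit of the assay. The two compounds share a core and differ in one group; going from one to the other gives an at least 260-fold lower number from compound 1 to compound 2 (2.42 log units; beyond the scatter), a step that begins at the limit of > 100000 nM in this assay, at which 1 of the 2 values shown sits, so its true size is not known. Compound 3, `Cc1cc(-c2nc(C(c3ccc(F)cc3)c3ccc(F)cc3)sc2CC(=O)O)ccn1`, has not yet been measured. Compared with compound 2 the change is methyl in place of methoxy on an aromatic carbon. Among the compounds with values here, no measured step exchanges methoxy for methyl; the only measured step at this part of the core swaps azetidin-1-yl for methoxy, a large step, and compound 3 carries neither of those groups. A modest step, within or close to the scatter, is therefore expected, most likely toward a somewhat higher number. Compound 3 is expected to give 700 nM, between 200 nM and 2500 nM, which means an expected step of a 1.8-fold higher number from compound 2 to compound 3 (0.27 log units; within the scatter).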

Compound 3, half-maximal inhibitory concentration: 53 nM
Estimate against measurement, compound 3: 13-fold (1.12 log units) above; measured number below the stated range.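

In this assay, the exchange of methoxy for methyl gives a 7.2-fold lower number from compound 2 to compound 3 (0.86 log units; beyond the scatter), so this position, next to the ring nitrogen, responds clearly even to a small change and not only to the large swap from azetidin-1-yl. The oxygen of methoxy and its hydrogen-bond acceptor are also not required for a low number here, since methyl has neither and compound 3 still gives the lowest number of the three. The other new step, an at least 1800-fold lower number from compound 1 to compound 3 (3.27 log units; beyond the scatter), starts from a limit, so its true size cannot be read: the limit of > 100000 nM in this assay, at which 1 of the 3 values shown sits.

Going by these compounds alone, these three compounds give only a single pair of small groups at this position, so they cannot show whether the gain comes from losing the oxygen or from having fewer heavy atoms there. From the compounds shown here alone, whether the number would fall further or rise again with ethyl, chlorine, trifluoromethyl or a plain hydrogen at the same place remains open, as does whether the preference for methyl over methoxy would hold on a different core.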